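Dichlorophenyl for dimethylphenyl at the assay limit

This account rests on a few compounds, and the source may have more. Where it says the series, first, only, none or still open, it means among the compounds named here.

In a functional assay on Jurkat cells (Homo sapiens) (a higher number here means a weaker inhibitor, a lower number a stronger inhibitor), compound 1 `C[C@H](NC(=O)C(=O)NCCC1CCCC1)C(=O)N[C@@H](CC(=O)O)C(=O)COc1c(F)c(F)cc(F)c1F` gives 11 nM. Compound 2 `Cc1ccc(CNC(=O)C(=O)N[C@@H](C)C(=O)N[C@@H](CC(=O)O)C(=O)COc2c(F)c(F)cc(F)c2F)cc1C` gives > 10000 nM, which is a limit of the assay and not a number. Compound 3 `C[C@H](NC(=O)C(=O)NCc1cc(Cl)cc(Cl)c1)C(=O)N[C@@H](CC(=O)O)C(=O)COc1c(F)c(F)cc(F)c1F` differs from compound 2 as follows: 3,5-dichlorophenyl in place of 3,4-dimethylphenyl on a saturated chain carbon bound to an amide-type nitrogen. Among the compounds with values here, the one measured step at this place is an at least 900-fold higher number from compound 1 to compound 2 (2.95 log units; beyond the scatter), and it brought in an aromatic ring. Compound 3 keeps an aromatic ring there, so only a modest move to a lower number is expected in this assay. Within the data shown here, no measured step exchanges one substituted phenyl for another. The expected step is an at least 2.0-fold lower number from compound 2 to compound 3 (0.30 log units; that floor lies within the scatter). For compound 3 the estimated value is 5000 nM, with an expected range of 500 nM to 20000 nM.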

Compound 3, half-maximal inhibitory concentration: 23 nM
The estimate for compound 3 lay 220-fold (2.34 log units) above the measured number; measured number below the stated range.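

In this assay, an aromatic ring at this position does not by itself bring the loss seen with 3,4-dimethylphenyl: 3,5-dichlorophenyl in its place gives an at least 430-fold lower number from compound 2 to compound 3 (2.63 log units; beyond the scatter). Against cyclopentylmethyl, 3,5-dichlorophenyl gives only a 2.1-fold higher number from compound 1 to compound 3 (0.32 log units; beyond the scatter). The value of compound 2 is a limit and not a number, and the first step therefore has only a floor: the limit of > 10000 nM in this assay, at which 1 of the 3 values shown sits.

The ring atoms and their placement change together here, leaving open which of them matters. A 3,5-dimethylphenyl or a 3,4-dichlorophenyl group at this position would separate the two.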